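Notes on the step from compound 1 to compound 4

The source may report more compounds than this note shows. Statements on the series, on what has been measured and on what is new or still open speak of the compounds shown alone.

compound 1 `COc1cc(C(=O)N2[C@@H](c3nccs3)[C@@H](C(N)=O)C[C@@]2(CC(C)C)C(=O)O)ccc1C(C)(C)C` gives 0.6% 
compound 2 `CCOC[C@H]1C[C@@](CC(C)C)(C(=O)O)N(C(=O)c2ccc(C(C)(C)C)c(OC)c2)[C@H]1c1nccs1` gives 120% 
compound 3 `COC[C@@H]1C[C@@](CC(C)C)(C(=O)O)N(C(=O)c2ccc(C(C)(C)C)c(OC)c2)[C@H]1c1nccs1` gives 44% 

All three values come from an in vivo ADME assay on the whole organism (strain Sprague-Dawley) for pharmacokinetics, with Rattus norvegicus as the target (a higher number here means that a larger share of the oral dose reaches the circulation, a lower number that a smaller share of the oral dose reaches the circulation), and compound 1 stands lowest among them, with compound 3 and compound 2 both higher by margins beyond the scatter.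

The next compound to consider is compound 4 `CC(C)C[C@@]1(C(=O)O)C[C@H](C(N)=O)[C@H](c2nccs2)N1C(=O)c1ccc(C(C)(C)C)cc1` which keeps the carbamoyl group of compound 1 and differs on the aromatic ring. The change is hydrogen in place of methoxy on an aromatic carbon and amounts to hydrogen in place of methoxy on an aromatic carbon, ortho to a tert-butyl group.

Within the data shown here, only one measured step bears on this, and only indirectly. That step is a number 119.4 percentage points higher from compound 1 to compound 2 (beyond the scatter) and it is large, but it concerns ethoxymethyl in place of carbamoyl on a saturated ring carbon, a different place from the one changed here. Every measured compound carries the methoxy, so the data hold no direct test of its removal. Among the measured compounds, only compound 1 carries the carbamoyl group, and compound 1 at 0.6% is the one basis for expecting compound 4 to stay low. The estimated step is a number 2.4 percentage points higher from compound 1 to compound 4 (within the scatter) and no move beyond the scatter is expected. Compound 4 is estimated at 3% and the expected range runs from 0.3% to 12% as the plausible span.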

Compound 4, oral bioavailability: 2%
Compound 4: middle estimate off by 1 percentage points, on the high side; the range from low to high includes it.
By their numbers in this assay, from the lowest: compounds 1 and 4 (each within the scatter of the next); then compound 3; then compound 2.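

In this assay the series now has a direct test of hydrogen in place of methoxy on an aromatic carbon, ortho to a tert-butyl group, and the reading is a number 1.4 percentage points higher from compound 1 to compound 4 (within the scatter). With the carbamoyl group held, this position therefore shows no move beyond the scatter, whereas the change on the saturated ring carbon gives a number 119.4 percentage points higher from compound 1 to compound 2 (beyond the scatter), so of the two places tested only the latter has shifted the oral read-out so far. Nothing in the data gives a reason for either reading.

From the compounds shown here alone, the methoxy test so far rests only on the carbamoyl-bearing pair, where compound 1 gives 0.6%, so it remains open whether hydrogen in place of methoxy would also stay within the scatter in the ethoxymethyl setting of compound 2, where there is far more room for a drop. Also open, going by these compounds, is what other groups on this aromatic carbon would do, such as a hydroxyl, an amine, a fluorine atom or a longer alkoxy chain, in either setting.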